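A Pyridinyl Ethenyl Arm Replaces a Methyl on the Core

A few compounds are considered here, and "the series" means these few. Any claim that something is new, unique, unknown or untested is made for them only; others in the source may bear on it.

Compound 1 `Cc1ccc(NC(=O)COc2nc3ccccc3nc2C)cc1` carries an anilide tail and a small methyl group on its fused core. In a functional assay on K562 cells (Homo sapiens) for inhibition, read by MTT assay, with a stated time of 24 h (a lower number here means a stronger inhibitor, a higher number a weaker inhibitor), compound 1 gives > 100000 nM, which is a limit of the assay rather than a measured number. Its only partner with data, compound 2 `Cc1nc2ccccc2nc1OCC(=O)Nc1ccc(Cl)cc1`, differs by a chloro in place of methyl on an aromatic carbon of the tail. In this assay compound 2 also gives > 100000 nM, again a limit. The step that the two limits leave unreadable from compound 1 to compound 2 therefore cannot be read, and the picture so far is summed up by the limit of > 100000 nM in this assay, at which 2 of the 2 values shown sit. Compound 3 `Cc1ccc(NC(=O)COc2nc3ccccc3nc2/C=C\c2ccncc2)cc1` is not yet measured. It differs from compound 1 in one place: 2-(pyridin-4-yl)ethenyl in place of methyl on an aromatic carbon. Among the compounds with values here, no measured step touches this part of the core, so nothing in the data says how large an effect to expect, only that both known compounds sit at the limit. On that basis compound 3 is expected to remain weak, with the step of an at least 2.0-fold lower number from compound 1 to compound 3 (0.30 log units; that floor lies within the scatter) likely small or unreadable. The estimate for compound 3 is 50000 nM, within 5000 nM to 200000 nM.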

Compound 3, half-maximal inhibitory concentration: > 100000 nM
Compound 3 was reported as a limit (the forecaster's own chance of this, stated with the estimate: 55%); middle value at least 2.0-fold (0.30 log units) away from the limit.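

Compound 1 and compound 3 both stand at a limit in this assay, so the step of 2-(pyridin-4-yl)ethenyl in place of methyl cannot be read. All the compounds shown share one result: the limit of > 100000 nM in this assay, at which 3 of the 3 values shown sit. They leave open whether any change to the tail or the shared core would give a measurable number.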